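The source may hold more compounds than are shown below. What is called first, only, known or untested is meant among the compounds shown, and "the series" means these compounds.

Measured so far in an assay on isolated protein for inhibition of histamine H2 receptor (Cavia porcellus); a lower number here means tighter binding, a higher number weaker binding:
compound 1, `CC(C)CNC(=O)NCCCOc1cccc(CN2CCCCC2)c1`: 170 nM
compound 2, `COc1ccc(OC)c(NC(=O)NCCCOc2cccc(CN3CCCCC3)c2)c1`: 158 nM
compound 3, `CCCNC(=O)NCCCOc1cccc(CN2CCCCC2)c1`: 97.7 nM

Compound 1 gives the highest of the three numbers, but its steps to the other two stay within the scatter: a 1.1-fold lower number from compound 1 to compound 2 (0.03 log units; within the scatter) and a 1.7-fold lower number from compound 1 to compound 3 (0.24 log units; within the scatter). The remaining step, a 1.6-fold lower number from compound 2 to compound 3 (0.21 log units; within the scatter), is within the scatter as well, so the three measured compounds are not separated in this assay.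

Compound 4, `O=C(NCCCOc1cccc(CN2CCCCC2)c1)Nc1cccc(Cl)c1`, is not yet measured. It differs from compound 1 in one place: 3-chlorophenyl in place of isobutyl on an amide-type nitrogen. The measured step that bears on this is a 1.1-fold lower number from compound 1 to compound 2 (0.03 log units; within the scatter), where 2,5-dimethoxyphenyl replaces isobutyl on the same amide-type nitrogen and the number barely moves. Going by the values given here, no measured compound carries 3-chlorophenyl on this nitrogen, so nothing points to a departure from that picture. The expectation for compound 4 is therefore a step of a 1.2-fold lower number from compound 1 to compound 4 (0.08 log units; within the scatter) in this assay, not beyond the scatter. Compound 4 is estimated at 140 nM, with a range of 60 nM to 330 nM.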

Compound 4, dissociation constant: 316 nM
Beside the measured number, compound 4's estimate is 2.3-fold (0.35 log units) below it; low and high end bracket the measured number.
By their numbers in this assay, from the lowest: compounds 3, 2, 1 and 4 (each within the scatter of the next, the first and the last beyond it).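

In this assay, going by these compounds alone, 3-chlorophenyl in place of propyl on the amide-type nitrogen gives a 3.2-fold higher number from compound 3 to compound 4 (0.51 log units; beyond the scatter), the first step beyond the scatter, so the group on this nitrogen can separate two compounds, though only modestly. Within the data shown here, the other two steps, a 1.9-fold higher number from compound 1 to compound 4 (0.27 log units; within the scatter) and a 2.0-fold higher number from compound 2 to compound 4 (0.30 log units; within the scatter), stay within the scatter, so 3-chlorophenyl is not separated from isobutyl or 2,5-dimethoxyphenyl, and only the pair of compound 3 and compound 4 is resolved. No measured evidence on the compounds accounts for that one separated step.

As far as these compounds go, whether the chlorine or the aromatic ring goes with the step stays open, and a plain phenyl group on this nitrogen would address that. From the compounds shown here alone, how a longer chain such as hexyl would compare with propyl on the same nitrogen also remains open.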